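A few compounds are considered here, and "the series" means these few. Any claim that something is new, unique, unknown or untested is made for them only; others in the source may bear on it.

Of the compounds shown here, three in a shared series have been measured in a functional assay on HL-60 cells (Homo sapiens) for inhibition, read by resazurin assay, with a stated time of 72 h (a lower number here means a stronger inhibitor, a higher number a weaker inhibitor), and a fourth awaits its number.

Compound 2, `C=CC1C(=O)N(c2cc(OC)c(OC)c(OC)c2)C1c1ccc(SC)cc1`, gives 61 nM. Compound 1, `COc1cc(N2C(=O)CC2c2ccc(SC)cc2)cc(OC)c1OC`, differs from compound 2 in one place: hydrogen in place of vinyl on a saturated ring carbon. That step, a 1.1-fold higher number from compound 2 to compound 1 (0.05 log units; within the scatter), is small, and compound 1 gives 69 nM. Compound 3, `C=CC1C(=O)N(c2cc(OC)c(OC)c(OC)c2)C1c1ccc(OCC)cc1`, differs from compound 2 at the aromatic ring instead: ethoxy in place of methylsulfanyl on an aromatic carbon. The step of a 1.7-fold lower number from compound 2 to compound 3 (0.24 log units; within the scatter) is again small, and compound 3 gives 35 nM.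

Compound 4, `CCOc1ccc(C2CC(=O)N2c2cc(OC)c(OC)c(OC)c2)cc1`, has not yet been measured. From compound 3 to compound 4 the difference is hydrogen in place of vinyl on a saturated ring carbon. This is the same kind of change as from compound 2 to compound 1, though not the same: around the place, the ring atom that bears a large group carries a 4-ethoxyphenyl group (9 heavy atoms) in compound 3 and compound 4, but a 4-(methylsulfanyl)phenyl group (8 heavy atoms) in compound 2 and compound 1. The two cores differ as told by ethoxy in place of methylsulfanyl on an aromatic carbon.

Because the earlier step of a 1.1-fold higher number from compound 2 to compound 1 (0.05 log units; within the scatter) stayed within the scatter, the step from compound 3 to compound 4 is expected to be similar, about a 1.1-fold higher number from compound 3 to compound 4 (0.04 log units; within the scatter). Compound 4 is therefore estimated to give about 38 nM, with a range expected between 20 nM and 75 nM.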

Compound 4, half-maximal inhibitory concentration: 88 nM
The estimate for compound 4 lay 2.3-fold (0.36 log units) below the measured number; the measured number lies above the stated range.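

In this assay, putting hydrogen in place of vinyl on the ethoxy-bearing core gives a 2.5-fold higher number from compound 3 to compound 4 (0.40 log units; beyond the scatter); this step alone lies beyond the usual scatter, while its counterpart on the methylsulfanyl-bearing core does not, yet set side by side the two cannot be told apart: the same change on two cores in this assay, a 1.1-fold higher number (0.05 log units; within the scatter) from compound 2 to compound 1 and a 2.5-fold higher number (0.40 log units; beyond the scatter) from compound 3 to compound 4, 2.2-fold (0.35 log units) apart, within the scatter of two such steps

With no vinyl present, putting ethoxy in place of methylsulfanyl gives a 1.3-fold higher number from compound 1 to compound 4 (0.11 log units; within the scatter), and this change also reads the same on both cores: the same change on two cores in this assay, a 1.7-fold lower number (0.24 log units; within the scatter) from compound 2 to compound 3 and a 1.3-fold higher number (0.11 log units; within the scatter) from compound 1 to compound 4, 2.2-fold (0.35 log units) apart, within the scatter of two such steps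

So, as far as these four compounds can tell, each change carries from one core to the other, but this rests on a single pair of steps per change, which neither proves that the effect is independent of the core nor rules out a real, modest dependence on it.

The compounds shown leave open how other groups would behave on that saturated ring carbon, such as an ethyl group, a longer chain or an amine, in place of vinyl. They also leave open whether the same agreement would hold with a different group on the aromatic ring, such as a hydroxy group or a longer alkoxy chain in place of ethoxy.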